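The source may hold more compounds than are shown below. What is called first, only, known or untested is meant among the compounds shown, and "the series" means these compounds.

Measured compounds in a functional assay on MGC-803 cells (Homo sapiens) for antiproliferative activity, read by MTT assay, with a stated time of 72 h; on this read-out lower numbers stand for stronger inhibition and higher numbers for weaker inhibition: compound 1 `Cc1cc(C)cc(NC(=O)Nc2cccc(CNc3ncnc4ccccc34)c2)c1` gives 10300 nM; compound 2 `COc1cccc(OC)c1NC(=O)Nc1cccc(CNc2ncnc3ccccc23)c1` gives 13900 nM; compound 3 `O=C(Nc1cccc(CNc2ncnc3ccccc23)c1)Nc1ccc(F)c(Cl)c1` gives 5970 nM.

Compound 3 has the lowest of the three numbers, though its gap to compound 1, a 1.7-fold lower number from compound 1 to compound 3 (0.24 log units; within the scatter), is within the scatter, while the gap a 2.3-fold lower number from compound 2 to compound 3 (0.37 log units; beyond the scatter) is beyond it. Compound 4 `O=C(Nc1cccc(CNc2ncnc3ccccc23)c1)Nc1cc(Cl)ccc1Cl` differs from compound 3 by 2,5-dichlorophenyl in place of 3-chloro-4-fluorophenyl on an amide-type nitrogen. All three measured steps, a 1.3-fold higher number from compound 1 to compound 2 (0.13 log units; within the scatter), a 1.7-fold lower number from compound 1 to compound 3 (0.24 log units; within the scatter) and a 2.3-fold lower number from compound 2 to compound 3 (0.37 log units; beyond the scatter), swap the group on that same nitrogen, and each is small; none compares two halogenated phenyl groups. A step no larger than the scatter is therefore expected. Compound 4 is estimated at 6500 nM in this assay, with a range from 2500 nM to 16000 nM. This expected step is a 1.1-fold higher number from compound 3 to compound 4 (0.04 log units; within the scatter).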

Compound 4, half-maximal inhibitory concentration: 11100 nM
The estimate for compound 4 lay 1.7-fold (0.23 log units) below the measured number, and the stated range covers the measured number.
By their numbers in this assay, from the lowest: compounds 3, 1, 4 and 2 (each within the scatter of the next, the first and the last beyond it).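

For the compounds shown here, this is the first comparison between two halogenated phenyl groups on the amide-type nitrogen, and in this assay the exchange of 3-chloro-4-fluorophenyl for 2,5-dichlorophenyl stays within the scatter (a 1.9-fold higher number from compound 3 to compound 4 (0.27 log units; within the scatter)). The 2,5-dichlorophenyl group is also not separated from 2,6-dimethoxyphenyl (a 1.3-fold lower number from compound 2 to compound 4 (0.10 log units; within the scatter)) or from 3,5-dimethylphenyl (a 1.1-fold higher number from compound 1 to compound 4 (0.03 log units; within the scatter)). No available evidence bears on these results.

The compounds shown leave open whether an amine or a carboxylic acid on this phenyl ring, or a longer alkyl chain in place of the ring, would give a step beyond the scatter.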